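Swapping a Furan Ring for Phenyl on the Saturated Core

This account rests on a few compounds, and the source may have more. Where it says the series, first, only, none or still open, it means among the compounds named here.

Measured compounds:
compound 1 `c1ccc(N2N=C(c3ccc4c(c3)OCCO4)CC2c2ccco2)cc1`: > 100000 nM
compound 2 `Ic1ccc(C2CC(c3ccc4c(c3)OCCO4)=NN2c2ccccc2)cc1`: 3470 nM
compound 3 `c1ccc(COc2cccc(C3CC(c4ccc5c(c4)OCCO5)=NN3c3ccccc3)c2)cc1`: 870 nM.

Compound 1 has only a limit in a functional assay on WM 266-4 cells (Homo sapiens) for antiproliferative activity, read by MTT assay, with a stated time of 24 h; on this read-out lower numbers stand for stronger inhibition of growth and higher numbers for weaker inhibition of growth: > 100000 nM (the limit of > 100000 nM in this assay, at which 1 of the 3 values shown sits). Compound 2 gives 3470 nM in this assay, and compound 3 gives 870 nM. Compound 4 `c1ccc(C2CC(c3ccc4c(c3)OCCO4)=NN2c2ccccc2)cc1` differs from compound 1 by phenyl in place of furan-2-yl on a saturated ring carbon. Among the compounds with values here, the only measured step at that position is an at least 28-fold lower number from compound 1 to compound 2 (1.45 log units; beyond the scatter), a large gain in growth inhibition. Compound 4 carries a plain phenyl without the iodine of compound 2, so a gain in the same direction, yet smaller, is expected. Compound 4 is therefore estimated at 10000 nM in this assay, with an expected range from 2500 nM to 50000 nM, which would mean an expected step of an at least 10-fold lower number from compound 1 to compound 4 (1.00 log units; beyond the scatter).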

Compound 4, concentration for 50% growth inhibition: 22400 nM
For compound 4 the middle estimate is 2.2-fold (0.35 log units) below the measured one, and the stated range covers the measured number.
By their numbers in this assay, from the lowest: compound 3; then compound 2; then compound 4. At a limit, above all of these: compound 1.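

Phenyl on this saturated ring carbon already beats furan-2-yl without any further group, with an at least 4.4-fold lower number from compound 1 to compound 4 (0.64 log units; beyond the scatter) in this assay. The true size of that step stays unknown, as compound 1 stands at a limit: the limit of > 100000 nM in this assay, at which 1 of the 4 values shown sits.

The plain phenyl also shows how much the added groups matter: hydrogen in place of iodo gives a 6.5-fold higher number from compound 2 to compound 4 (0.81 log units; beyond the scatter), and hydrogen in place of benzyloxy gives a 26-fold higher number from compound 3 to compound 4 (1.41 log units; beyond the scatter).

As far as these compounds go, how an amine or a carboxylic acid on that phenyl would compare remains open. Iodo and benzyloxy differ in both kind and place, so the two effects cannot be separated.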